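This account rests on a few compounds, and the source may have more. Where it says the series, first, only, none or still open, it means among the compounds named here.

Measured so far in a functional assay on CCRF-CEM cells (Homo sapiens) for cytotoxicity, read by cell counting, with a stated time of 3 days; a higher number here means a weaker inhibitor, a lower number a stronger inhibitor:
- compound 1 `Nc1ccc(/C=C2\SC(=O)N(Cc3cccc(Cl)c3)C2=O)cc1` gives 18000 nM
- compound 2 `CCN1C(=O)S/C(=C\c2ccc(N)cc2)C1=O` gives 91000 nM

Among the measured compounds shown here, compound 2 holds the highest of the two numbers in this assay; compound 1 is the only neighbour, and the single measured step, a 5.1-fold higher number from compound 1 to compound 2 (0.70 log units; beyond the scatter), separates them.

Compound 3 `Cc1ccc(CN2C(=O)S/C(=C\c3ccc(N)cc3)C2=O)cc1` differs from compound 2 in one place: 4-methylphenyl in place of methyl on a saturated chain carbon bound to an amide-type nitrogen in a ring. For the measured compounds named here, the one step that bears on this change is a 5.1-fold higher number from compound 1 to compound 2 (0.70 log units; beyond the scatter), in which the same saturated chain carbon bound to the amide-type nitrogen exchanged 3-chlorophenyl for methyl. Compound 3 goes the other way, putting an aryl ring back in place of methyl, though as 4-methylphenyl rather than 3-chlorophenyl. A lower number in this assay is therefore expected, of roughly the size of that step run backwards, a 4.6-fold lower number from compound 2 to compound 3 (0.66 log units; beyond the scatter). Whether the methyl-bearing ring equals the chloro-bearing one cannot be settled from compounds 1 and 2 alone, so the range is kept wide. Compound 3 is expected at 20000 nM, within 8000 nM to 50000 nM.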

Compound 3, half-maximal inhibitory concentration: > 250000 nM
Compound 3: a limit, no number; the forecaster's own chance of this, stated with the estimate: 5%; middle value at least 12-fold (1.09 log units) from the limit.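

In this assay compound 3 carries a limit, not a number: the limit of > 250000 nM in this assay, at which 1 of the 3 values shown sits.

Even as a limit, this reading shows that an aryl ring in place of methyl on the saturated chain carbon does not in itself give a lower number, since 4-methylphenyl moves the other way: an at least 2.7-fold higher number from compound 2 to compound 3 (0.43 log units; beyond the scatter). Exchanging one aryl group for the other at this place also matters, with 4-methylphenyl in place of 3-chlorophenyl giving an at least 13-fold higher number from compound 1 to compound 3 (1.14 log units; beyond the scatter), so among these compounds the outcome depends on which substituted ring is present.

On these data alone, how far the number of compound 3 lies beyond its limit stays open, and with it the true size of both steps. Also open, as far as these compounds go, is whether the chlorine or the ring position of the substituent governs the difference, which a 4-chlorophenyl or 3-methylphenyl group at this place would separate.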